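This account rests on a few compounds, and the source may have more. Where it says the series, first, only, none or still open, it means among the compounds named here.

Measured compounds in an assay for inhibition of Polyunsaturated fatty acid 5-lipoxygenase (Homo sapiens), read by HPLC, with stated times of 15 min and 10 min; a lower number here means a stronger inhibitor, a higher number a weaker inhibitor:
compound 1 `Cc1ccc(C(=O)NCc2ccccc2C(F)(F)F)cc1C#CC(C)N(O)C(N)=O` — 1700 nM
compound 2 `CC(C#Cc1cccc(C(=O)NCCC(c2ccccc2)c2ccccc2)c1)N(O)C(N)=O` — 300 nM
compound 3 `CC(C#Cc1cccc(C(=O)NCCC(c2ccccc2)c2ccc(F)cc2)c1)N(O)C(N)=O` — 160 nM

Compound 3 has the lowest of the three numbers, but its gap to compound 2 lies within the scatter, so the two are not separated; compound 1 stands beyond the scatter at the high end. Compound 4 `CC(C#Cc1cccc(C(=O)NCCC(c2ccccc2)c2ccc(Cl)cc2)c1)N(O)C(N)=O` is not yet measured. From compound 3 it differs by chloro in place of fluoro on an aromatic carbon. Going by the values given here, the only measured step that bears on this change is a 1.9-fold lower number from compound 2 to compound 3 (0.27 log units; within the scatter), which stays within the scatter. Among the compounds with values here, no measured pair shows chloro in place of fluoro, so the expectation rests on that single small step and on the closeness of compound 2 and compound 3. No step beyond the scatter is therefore expected in this assay; if anything, a slightly lower number. For compound 4 the expected value is 130 nM, with a range of 50 nM to 400 nM. The expected step is accordingly a 1.2-fold lower number from compound 3 to compound 4 (0.09 log units; within the scatter).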

Compound 4, half-maximal inhibitory concentration: 120 nM
Compound 4: middle estimate off by 1.1-fold (0.03 log units), on the high side; measured number inside the range.
By their numbers in this assay, from the lowest: compounds 4, 3 and 2 (each within the scatter of the next, the first and the last beyond it); then compound 1.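

In this assay the change from 4-fluorophenyl to 4-chlorophenyl gives a 1.3-fold lower number from compound 3 to compound 4 (0.12 log units; within the scatter), so the two halogens are not separated at this place, para to a large group. Chloro in place of hydrogen gives a 2.5-fold lower number from compound 2 to compound 4 (0.40 log units; beyond the scatter), a modest step but the first at this place to pass the scatter, which fluoro in place of hydrogen did not do. No evidence is at hand on what lies behind these steps.

Open, going by these compounds, is whether a bromo, methyl, methoxy or trifluoromethyl group at this place would carry the step from hydrogen further. Also open, on these data alone, is whether chloro on the other aromatic ring, or on both, would give a step beyond the scatter from compound 4.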